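Two values and a swap of the large group

A few compounds are considered here, and "the series" means these few. Any claim that something is new, unique, unknown or untested is made for them only; others in the source may bear on it.

Measured in an ADME assay on the whole organism (strain Sprague-Dawley) for pharmacokinetics, with Rattus norvegicus as the target, at a dose of 1 mg/kg by the intravenous route; a lower number here means that more of the compound stays in the plasma, a higher number that more of the compound sits outside the plasma:
- compound 1 `COc1cc2nccc(Oc3ccc(NC(=O)c4c(-c5ccccc5)n(C)n(-c5ccccc5)c4=O)nc3)c2cc1OC`: 0.73 L/kg
- compound 2 `Cc1ncc2ccc(Oc3c(C)ccc(C(=O)c4c(-c5ccccc5)n(C)n(-c5ccccc5)c4=O)c3N)cc2n1`: 2.6 L/kg

Compound 2, at 2.6 L/kg, holds the higher of the two values. Compound 1, at 0.73 L/kg, lies lower, and the gap is beyond the scatter. The two compounds differ in more than one place, so this gap isolates no single group.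

Compound 3 `Cc1ccc(C(=O)c2c(-c3ccccc3)n(C)n(-c3ccccc3)c2=O)c(N)c1-c1ccc2nc(C(F)F)sc2c1` follows from compound 2 by one change: 2-(difluoromethyl)-1,3-benzothiazol-6-yl in place of (2-methylquinazolin-7-yl)oxy on an aromatic carbon, ortho to a methyl group and ortho to an amino group (2-(difluoromethyl)-1,3-benzothiazol-6-yl in place of (2-methylquinazolin-7-yl)oxy on an aromatic carbon). For the measured compounds named here, no measured pair shows what such a replacement does, so the expectation is anchored on compound 2 at 2.6 L/kg, the only measured compound that differs from compound 3 in this one place. No step beyond the scatter is expected in this assay, with a small downward lean allowed for. The expected change is a 1.4-fold lower number from compound 2 to compound 3 (0.14 log units; within the scatter). For compound 3 the estimated value is 1.9 L/kg, with an expected range of 0.8 L/kg to 4.5 L/kg.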

Compound 3, volume of distribution at steady state: 5 L/kg
Compound 3: middle estimate off by 2.6-fold (0.42 log units), on the low side; the whole stated range lies below it.
By their numbers in this assay, from the lowest: compound 1; then compounds 2 and 3 (each within the scatter of the next).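

In this assay, for the compounds shown here, placing 2-(difluoromethyl)-1,3-benzothiazol-6-yl instead of (2-methylquinazolin-7-yl)oxy on the aromatic carbon ortho to a methyl group and ortho to an amino group gives a 1.9-fold higher number from compound 2 to compound 3 (0.28 log units; within the scatter) as the first one-place comparison. At this position, then, the whole large group can be exchanged, with the oxygen link dropped and sulfur and fluorine brought in, and the two compounds still lie within the usual scatter of each other. No measurement shown here explains the read-out of either compound.

Compounds 2 and 3 leave open what the loss of the oxygen link and the exchange of the ring groups each contribute alone, as the two travel together in this single step. Also open, going by these compounds, is how a trifluoromethyl group, or a carboxylic acid or an amine, in place of the difluoromethyl group on the 1,3-benzothiazol-6-yl group would read in this assay on the same core.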